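Adding trifluoromethyl to compound 1: what to expect

The source may hold more compounds than are shown below. What is called first, only, known or untested is meant among the compounds shown, and "the series" means these compounds.

Measured so far in a functional assay on A2780 cells (Homo sapiens) for antiproliferative activity, read by fluorescence, with a stated time of 72 h; a higher number here means a weaker inhibitor, a lower number a stronger inhibitor:
compound 1 `CN1CCC(C(=O)N2Cc3c(NC(=O)c4ccccc4)n[nH]c3C2(C)C)CC1` gives 160 nM
compound 2 `CC(C)(C)C(=O)N1Cc2c(NC(=O)c3cccnc3)n[nH]c2C1(C)C` gives 690 nM
compound 3 `CN(C)CC(=O)Nc1n[nH]c2c1CN(C(=O)C(C)(C)C)C2(C)C` gives 580 nM

Among these three, compound 1 stands lowest: compound 3 is the nearest of the others and compound 2 the furthest, and both gaps lie beyond the scatter. Going by the values given here, the only step between compounds that differ in one place is a 1.2-fold lower number from compound 2 to compound 3 (0.08 log units; within the scatter), which lies within the scatter; it concerns (dimethylamino)methyl in place of pyridin-3-yl on a carbonyl carbon and does not touch the change now at hand. Compound 4 `CN1CCC(C(=O)N2Cc3c(NC(=O)c4ccc(C(F)(F)F)cc4)n[nH]c3C2(C)C)CC1` differs from compound 1 by trifluoromethyl in place of hydrogen on an aromatic carbon. Among the compounds with values here, no measured pair shows what a trifluoromethyl on this aromatic carbon does, so nothing in the set argues for a step in either direction beyond the scatter. Relative to compound 1, the step expected for compound 4 is no change at the digits printed from compound 1 to compound 4 (within the scatter), with a wide range for want of a precedent. Compound 4 is estimated at 160 nM, between 50 nM and 500 nM.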

Compound 4, half-maximal inhibitory concentration: 60 nM
Beside the measured number, compound 4's estimate is 2.7-fold (0.43 log units) above it; measured number inside the range.
By their numbers in this assay, from the lowest: compound 4; then compound 1; then compounds 3 and 2 (each within the scatter of the next).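

In this assay, trifluoromethyl in place of hydrogen on an aromatic carbon, para to a large group, gives a 2.7-fold lower number from compound 1 to compound 4 (0.43 log units; beyond the scatter). Going by these compounds alone, this is the first step in the set at this position, and it shows that the ring carbon accepts a substituent of 4 heavy atoms with a gain rather than a loss, though it rests on this single pair. Nothing measured here bears on why the number falls.

Going by these compounds, whether a methyl, a chlorine or a nitrile on the same carbon would move the number as far, or in the same direction, remains open. Also open, on these data alone, is whether trifluoromethyl would give a similar step on another carbon of that ring, or with a different group on the carbonyl of the shared core.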